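Swapping a Hydroxy for a Nitro Group on the Pendant Phenyl

This account rests on a few compounds, and the source may have more. Where it says the series, first, only, none or still open, it means among the compounds named here.

Compound 1, `COc1cc(/C=C/C(=O)C2=C(/C=C/c3ccc(O)c(OC)c3)NC(=O)NC2c2ccccc2)ccc1O`: 26.4%
Compound 2, `COc1cc(/C=C/C(=O)C2=C(/C=C/c3ccc(O)c(OC)c3)NC(=O)NC2c2ccccc2O)ccc1O`: 73.6%
Compound 3, `COc1cc(/C=C/C(=O)C2=C(/C=C/c3ccc(O)c(OC)c3)NC(=O)NC2c2ccc(O)cc2)ccc1O`: 75%
Compound 4, `COc1cc(/C=C/C(=O)C2=C(/C=C/c3ccc(O)c(OC)c3)NC(=O)NC2c2cccc([N+](=O)[O-])c2)ccc1O`: not yet measured

Of the compounds shown here, three have been tested in a functional assay, with a stated time of 20 min, tested at 10 uM; a higher number here means a stronger effect of the compound at the concentration tested, a lower number a weaker effect. Compound 3 stands highest of the three, but compound 2 sits within the scatter of it, as a number 1.4 percentage points higher from compound 2 to compound 3 (within the scatter) shows, so the two cannot be told apart. Compound 1, which carries an unsubstituted phenyl on the saturated ring carbon, lies well below both: a number 47.2 percentage points higher from compound 1 to compound 2 (beyond the scatter) and a number 48.6 percentage points higher from compound 1 to compound 3 (beyond the scatter) are large steps, and each is simply a hydroxy in place of hydrogen on that aromatic ring.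

Compound 4 takes a different route: 3-nitrophenyl in place of 4-hydroxyphenyl on a saturated ring carbon. For the measured compounds named here, no measured step describes a nitro group at this position, so the only guide is that both measured gains came with a hydroxy, and compound 4 has none. Removing it from compound 3 is therefore expected to cost activity, with a number 35 percentage points lower from compound 3 to compound 4 (beyond the scatter) as the step estimated, although the size is uncertain. Compound 4 is expected to give about 40% in this assay, with a range of 20% to 65%.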

Compound 4, a percentage reported as activity, at one concentration (the size of the read-out at that concentration, not a potency): 51.2%
Compound 4: middle estimate off by 11.2 percentage points, on the low side; the measured number falls inside the stated range.
By their numbers in this assay, from the lowest: compound 1; then compound 4; then compounds 2 and 3 (each within the scatter of the next).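

The nitro group shows that a hydroxy is not needed for a gain on this phenyl: in this assay the 3-nitrophenyl, which has no hydrogen-bond donor, still lifts the number clearly above the unsubstituted phenyl (a number 24.8 percentage points higher from compound 1 to compound 4 (beyond the scatter)). The gain is smaller than with either hydroxy, and the gap is beyond the scatter against both hydroxy compounds (a number 23.8 percentage points lower from compound 3 to compound 4 (beyond the scatter); a number 22.4 percentage points lower from compound 2 to compound 4 (beyond the scatter)), so this position separates one substituent from another, where the two hydroxyphenyl compounds alone could not be told apart. Nothing given here accounts for these differences.

The 3-nitrophenyl differs from the two hydroxyphenyl groups both in the group itself and in where it stands on the ring, and the compounds shown do not separate those two changes. They also leave open how an amine, a methoxy or a carboxylic acid on this phenyl would read in this assay, and so whether the hydroxy or the nitro result is the more typical one for this position.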